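A Fluorine on the Phenyl Ring: A Small Step Expected

The compounds below may be only part of what the source reports. "The series", "measured", "known", "first", "only" and "open" are said of these compounds alone.

Compound 2 `Cc1ccc(N2CC(c3nc(-c4ccccc4)no3)CC2=O)cc1` is one of three compounds tested in an in vitro functional assay on HEK293-A cells for positive allosteric modulation of metabotropic glutamate receptor 5 (Homo sapiens), read by FLIPR and calcium flux; a higher number here means that more compound is needed for the effect, a lower number that less compound is needed. Compound 2 gives 384 nM, the highest of the three numbers, yet compound 1 `O=C1CC(c2nc(-c3ccccc3)no2)CN1c1ccccc1` gives 350 nM and compound 3 `Cc1cccc(-c2noc(C3CC(=O)N(c4ccc(C)c(Cl)c4)C3)n2)c1` gives 240 nM, both within the scatter of compound 2. For the measured compounds named here, the only single-point step among them, a 1.1-fold higher number from compound 1 to compound 2 (0.04 log units; within the scatter), came with methyl in place of hydrogen on an aromatic carbon. Compound 4 `Cc1ccc(N2CC(c3nc(-c4cccc(F)c4)no3)CC2=O)cc1` differs from compound 2 by fluoro in place of hydrogen on an aromatic carbon. Going by the values given here, no measured step places a fluoro on this ring, and the one step that is known changed nothing beyond the scatter, so in this assay no step beyond the scatter is expected, a 1.1-fold lower number from compound 2 to compound 4 (0.04 log units; within the scatter). Compound 4 is therefore estimated at 350 nM, with a likely range from 150 nM to 800 nM.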

Compound 4, half-maximal effective concentration: 1200 nM
Beside the measured number, compound 4's estimate is 3.4-fold (0.54 log units) below it, and the stated range ends below it.
By their numbers in this assay, from the lowest: compounds 3, 1 and 2 (each within the scatter of the next); then compound 4.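

In this assay, phenyl to 3-fluorophenyl gave a 3.1-fold higher number from compound 2 to compound 4 (0.49 log units; beyond the scatter), so adding a single fluorine atom to this ring means more compound is needed, by a step beyond the scatter. For the compounds shown here, the only earlier step, a 1.1-fold higher number from compound 1 to compound 2 (0.04 log units; within the scatter), put a methyl on the other phenyl ring and stayed within the scatter, so this ring responds to a change in a way the earlier compounds could not reveal. Nothing available explains the rise. Going by these compounds, whether it is specific to fluoro or would also follow from chloro, methoxy or an amine at this place remains open.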